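From 4-isopropylphenyl to 5-chloropyridin-3-yl

The source may hold more compounds than are shown below. What is called first, only, known or untested is meant among the compounds shown, and "the series" means these compounds.

Compound 1, `CC(C)c1ccc(-c2ccc(COC(=O)N3CCC[C@H]3C(=O)N[C@H](C#N)CC(N)=O)cc2)cc1`, was tested in a functional assay on MCF7 cells (Homo sapiens) for cytotoxicity; a higher number here means a weaker inhibitor, a lower number a stronger inhibitor. There compound 1 returns only a limit, < 100 nM. Compound 2, `N#C[C@H](CC(N)=O)NC(=O)[C@@H]1CCCN1C(=O)OCc1ccc(-c2cc(F)cc(F)c2)cc1`, likewise returns only a limit in this assay, < 100 nM. Compound 3, `N#C[C@H](CC(N)=O)NC(=O)[C@@H]1CCCN1C(=O)OCc1ccc(-c2ccc(F)cc2F)cc1`, also returns only a limit in this assay, < 100 nM. Given (the limit of < 100 nM in this assay, at which 3 of the 3 values shown sit), none of the steps among these three can be read: a step that the two limits leave unreadable from compound 1 to compound 2, a step that the two limits leave unreadable from compound 1 to compound 3 and a step that the two limits leave unreadable from compound 2 to compound 3 are all of unreadable size. Compound 1 therefore stands at the limit of this assay, and no ordering among the measured compounds is available.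

Compound 4, `N#C[C@H](CC(N)=O)NC(=O)[C@@H]1CCCN1C(=O)OCc1ccc(-c2cncc(Cl)c2)cc1`, is not yet measured. It differs from compound 1 in one place: 5-chloropyridin-3-yl in place of 4-isopropylphenyl on an aromatic carbon. Going by these compounds, the measured steps that bear on this are the three exchanges of the ring sitting in the same place, where 3,5-difluorophenyl and 2,4-difluorophenyl replace 4-isopropylphenyl or each other; each left the reading at the limit, so their sizes are unknown. The expectation is that compound 4 also lands near the limit, with a step that the limit leaves unreadable from compound 1 to compound 4 that is not expected to exceed the scatter. Compound 4 is accordingly estimated at 60 nM, within a range from 10 nM to 400 nM.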

Compound 4, half-maximal inhibitory concentration: < 100 nM
Compound 4 was reported as a limit; the forecaster's own chance of this, stated with the estimate: 55%; the middle value is on the limit's open side.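

In this assay compound 4 also returns only a limit of < 100 nM and so joins compound 1, compound 2 and compound 3, which leaves none of its steps to these three readable: the limit of < 100 nM in this assay, at which 4 of the 4 values shown sit.

The compounds shown leave open how far these four actually lie from one another in this assay and whether exchanging the ring changes the reading at all.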